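The source may report more compounds than this note shows. Statements on the series, on what has been measured and on what is new or still open speak of the compounds shown alone.

Compound 1 `CCCn1c(-c2ccccc2)nc2c(NC3CCCC3)ncnc21` is the reference point. In a functional assay on CHO cells for antagonist activity at adenosine receptor A2b (Homo sapiens), read by 33P incorporation, with a stated time of 20 min (a lower number here means a stronger inhibitor, a higher number a weaker inhibitor), compound 1 gives 3430 nM. Of the three numbers in hand this is the lowest, though not by a margin that holds throughout: compound 3 `CCCn1c(-c2ccccc2)nc2c(NC3CCCCC3)ncnc21` gives 5310 nM in this assay, and the step of a 1.5-fold higher number from compound 1 to compound 3 (0.19 log units; within the scatter) lies within the scatter. Within the data shown here, compound 2 `CCn1c(-c2ccccc2)nc2c(NC3CCOC3)ncnc21` gives 11500 nM in this assay; no single-point step links it to compound 1, so its number simply stands beside that of compound 1 and lies beyond the scatter from it.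

Compound 4 `Cn1c(-c2ccccc2)nc2c(NC3CCCC3)ncnc21` differs from compound 1 by hydrogen in place of ethyl on a saturated chain carbon bound to an aromatic nitrogen; cut one bond further out, the same difference reads propyl to methyl. Among the measured compounds shown here, none of the measured steps touches this chain. For the measured compounds named here, the one step in hand, a 1.5-fold higher number from compound 1 to compound 3 (0.19 log units; within the scatter), concerns the ring carried on a nitrogen on an aromatic ring, and it was small. The data therefore offer no measured guide to the size or direction of the change in this assay. Shortening the chain is expected to cost a little, an expected step of a 1.7-fold higher number from compound 1 to compound 4 (0.24 log units; within the scatter), with wide uncertainty. Compound 4 is accordingly estimated at 6000 nM in this assay, in the range 2000 nM to 20000 nM.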

Compound 4, inhibition constant: 8510 nM
Compound 4: middle estimate off by 1.4-fold (0.15 log units), on the low side; low and high end bracket the measured number.
By their numbers in this assay, from the lowest: compounds 1, 3, 4 and 2 (each within the scatter of the next, the first and the last beyond it).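

Shortening propyl to methyl on a saturated chain carbon bound to an aromatic nitrogen gives a 2.5-fold higher number from compound 1 to compound 4 (0.39 log units; beyond the scatter) in this assay, so this chain is the first place in the series where a single change is seen to move the number past the scatter, if only modestly. The earlier step on the ring carried on the nitrogen, a 1.5-fold higher number from compound 1 to compound 3 (0.19 log units; within the scatter), stayed within the scatter, so the two places in the molecule do not so far respond alike. No measurement is available to explain what lies behind the step on the chain, which therefore stands as an observation only.

The compounds shown leave open how the number runs along the chain, since only propyl and methyl can be compared on the cyclopentyl series, and compound 2, which carries ethyl, also differs in its ring on the nitrogen. Also open, from the compounds shown here alone, are whether a longer chain such as butyl would lower or raise the number, what a chain ending in an amine or a carboxylic acid would do, and whether the same step holds with cyclohexyl in place of cyclopentyl.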